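Notes on the aryl change from compound 2 to compound 3

The compounds below may be only part of what the source reports. "The series", "measured", "known", "first", "only" and "open" are said of these compounds alone.

Compound 2 `CC(Sc1nc2c(cnn2C)c(=O)n1-c1ccccc1)c1ccncc1` carries pyridin-4-yl on a saturated chain carbon bound to a saturated chain carbon and a sulfur. In an assay on isolated protein for inhibition of aldehyde dehydrogenase 1A1 (Homo sapiens) (on this read-out higher numbers stand for weaker inhibition and lower numbers for stronger inhibition), compound 2 gives 451 nM, the highest of the two numbers recorded so far. The nearest neighbour is compound 1 `CC(Sc1nc2c(cnn2C)c(=O)n1-c1ccccc1)c1ccccn1`, which in this assay gives 242 nM; the step of a 1.9-fold higher number from compound 1 to compound 2 (0.27 log units; within the scatter) lies within the scatter. Compound 3 `COc1ccc(C(C)Sc2nc3c(cnn3C)c(=O)n2-c2ccccc2)cc1` is not yet measured; it differs from compound 2 by 4-methoxyphenyl in place of pyridin-4-yl on a saturated chain carbon bound to a saturated chain carbon and a sulfur. Among the compounds with values here, the single measured step exchanges one pyridyl isomer for the other and does not replace the ring with 4-methoxyphenyl, so no measured step bears directly on this change. That step, a 1.9-fold higher number from compound 1 to compound 2 (0.27 log units; within the scatter), stayed within the scatter, which offers no direction for the present exchange, and the effect of replacing pyridin-4-yl by 4-methoxyphenyl in this assay is simply uncovered. The step of a 1.1-fold lower number from compound 2 to compound 3 (0.05 log units; within the scatter) is therefore expected to be small, with its direction undetermined and a wide margin either way. Compound 3 is estimated at 400 nM in this assay, within a range from 120 nM to 1500 nM.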

Compound 3, half-maximal inhibitory concentration: 352 nM
Compound 3: the middle estimate sits 1.1-fold (0.06 log units) above what was measured, within the range that was stated.
By their numbers in this assay, from the lowest: compounds 1, 3 and 2 (each within the scatter of the next).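

In this assay the exchange of pyridin-4-yl for 4-methoxyphenyl on a saturated chain carbon bound to a saturated chain carbon and a sulfur gives a 1.3-fold lower number from compound 2 to compound 3 (0.11 log units; within the scatter) and the exchange of pyridin-2-yl for the same group gives a 1.5-fold higher number from compound 1 to compound 3 (0.16 log units; within the scatter) so both steps stay within the scatter. The earlier pair compared only two pyridyl isomers, whereas these steps show that a six-membered aromatic ring of carbon only, bearing a methoxy group, can take the place of either pyridyl ring without a step beyond the scatter in these three compounds. No measurement is available here that would explain this outcome.

Within the data shown here, all the groups at this position so far are six-membered aromatic rings, so it remains open whether a plain phenyl, a saturated amine such as piperidin-4-yl or a carboxylic acid at the same place would give a step beyond the scatter. Also open, as far as these compounds go, is whether a 4-methoxyphenyl exchange would read the same way on a core with another group in place of the phenyl on the shared core.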